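Adding a Second Chloro to Compound 3

This account rests on a few compounds, and the source may have more. Where it says the series, first, only, none or still open, it means among the compounds named here.

compound 1, `Nc1scc(CN2CCN(c3ccc(Cl)cc3F)CC2)c1C(=O)c1ccc(Cl)cc1`, gives 1% in an assay on CHO cells for displacement of a labelled ligand from adenosine receptor A3 (Homo sapiens), read by scintillation counting, with a stated time of 120 min, tested at 10 uM; on this read-out lower numbers stand for less inhibition and higher numbers for more inhibition at the one concentration tested (going by the name of the read-out)
compound 2, `Nc1scc(CN2CCN(c3cccc(C(F)(F)F)c3)CC2)c1C(=O)c1ccc(Cl)cc1`, gives 0% in this assay
compound 3, `Nc1scc(CN2CCN(c3cccc(Cl)c3)CC2)c1C(=O)c1ccc(Cl)cc1`, gives 1% in this assay

Compound 3 stands level with compound 1 at the digits shown, and the two together hold the highest of the three numbers in this assay; compound 2 is the furthest from it. All three steps among the measured compounds stay within the scatter: no change at the digits printed from compound 1 to compound 3 (within the scatter), a number 1 percentage points higher from compound 2 to compound 3 (within the scatter) and a number 1 percentage points lower from compound 1 to compound 2 (within the scatter). Every measured number sits at the bottom of the scale.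

Compound 4, `Nc1scc(CN2CCN(c3ccc(Cl)c(Cl)c3)CC2)c1C(=O)c1ccc(Cl)cc1`, differs from compound 3 by chloro in place of hydrogen on an aromatic carbon. Among the compounds with values here, no measured step adds a group to an existing aryl ring in this way; the nearest comparisons are the swaps of the whole aryl group, which were all within the scatter. With three compounds at essentially the same low level, the account expects no step beyond the scatter, written as a number 1 percentage points higher from compound 3 to compound 4 (within the scatter). Compound 4 is therefore estimated to give 2% in this assay, with a range from -8% to 12%.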

Compound 4, a percentage reported as inhibition, at one concentration (the size of the read-out at that concentration, not a potency): 3%
For compound 4 the middle estimate is 1 percentage points below the measured one; the range from low to high includes it.
By their numbers in this assay, from the lowest: compounds 2, 1, 3 and 4 (each within the scatter of the next).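

Within the data shown here, the chloro added to compound 3, ortho to a chloro group and para to a large group, is the first addition to an existing aryl ring, and in this assay it gives a number 2 percentage points higher from compound 3 to compound 4 (within the scatter). The swaps of the whole aryl group read the same way, with a number 3 percentage points higher from compound 2 to compound 4 (within the scatter) and a number 2 percentage points higher from compound 1 to compound 4 (within the scatter), so the 3,4-dichlorophenyl group does not set compound 4 apart from the other three compounds. Nothing is available that bears on this result.

From the compounds shown here alone, all four compounds sit at the bottom of the scale, so it stays open whether this position can influence the read-out at all. Going by these compounds, what an amine or a carboxylic acid would give at this place on the ring also remains open, as does the effect of a change in the shared core.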